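The source may report more compounds than this note shows. Statements on the series, on what has been measured and on what is new or still open speak of the compounds shown alone.

Of the compounds shown here, three with a shared core have been measured in an ADME assay on MT4 cells (Homo sapiens) for cytotoxicity, read by MTT assay; a lower number here means that less compound is tolerated, a higher number that more compound is tolerated. Compound 1 `Cc1ccc(-n2ccnc2SCC(=O)Nc2ccccc2Cl)cc1` gives 33700 nM. Compound 2 `O=C(CSc1nccn1-c1cccc2ccccc12)Nc1ccccc1F` gives 34700 nM. Compound 3 `Cc1ccc(-n2ccnc2SCC(=O)Nc2ccccc2Br)cc1` gives 39300 nM. Among the compounds with values here, the only single change between measured compounds, bromo in place of chloro on an aromatic carbon, is a 1.2-fold higher number from compound 1 to compound 3 (0.07 log units; within the scatter). Compound 2 sits second highest of the three numbers, and its gaps to compound 1 and to compound 3 both lie within the scatter, so the three compounds cannot be told apart.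

Compound 4 `Cc1ccccc1NC(=O)CSc1nccn1-c1cccc2ccccc12` has not yet been measured. Compared with compound 2, the change is methyl in place of fluoro on an aromatic carbon. Within the data shown here, no measured step swaps fluoro for methyl; the one step available, from compound 1 to compound 3, exchanged one group for another on the same aromatic carbon and stayed within the scatter. On that basis no step beyond the scatter is expected in this assay, with the step from compound 2 to compound 4 estimated at a 1.0-fold higher number from compound 2 to compound 4 (0.00 log units; within the scatter). Compound 4 is therefore expected to give about 35000 nM, in the range 20000 nM to 65000 nM.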

Compound 4, half-maximal cytotoxic concentration: 34600 nM
Compound 4: middle estimate off by 1.0-fold (0.00 log units), on the high side; the measured number falls inside the stated range.
By their numbers in this assay, from the lowest: compounds 1, 4, 2 and 3 (each within the scatter of the next).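

In this assay, methyl in place of fluoro on an aromatic carbon ortho to a large group gives a 1.0-fold lower number from compound 2 to compound 4 (0.00 log units; within the scatter), so compound 2 and compound 4 cannot be told apart. The earlier step at this kind of place only exchanged one halogen for another, chloro for bromo, whereas this one puts a carbon group where a halogen stood, and on the core of compound 2, and it too stays within the scatter. No measured evidence bears on why these two groups read alike here.

On these data alone, it remains open whether a group of a different kind at this place, such as an amine, a carboxylic acid or a longer chain, would give a step beyond the scatter. The compounds shown also leave open whether the other parts of the shared core have any larger bearing on this number.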